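The compounds below may be only part of what the source reports. "The series", "measured", "known", "first", "only" and "open" are said of these compounds alone.

Compound 1 `Cc1nc(CS(=O)(=O)c2ccccc2)c([N+](=O)[O-])n1C`: > 846000 nM (a limit of the assay)
Compound 2 `Cc1nc(CS(=O)(=O)c2ccccc2)c([N+](=O)[O-])n1CC(C)O`: 418000 nM

Going by the values given here, in an ADME assay on THP-1 cells (Homo sapiens) for cytotoxicity, read by flow cytometry and propidium iodide staining, with a stated time of 72 h (on this read-out higher numbers stand for weaker inhibition and lower numbers for stronger inhibition), compound 2 gives 418000 nM, the only true number so far. Compound 1 gives > 846000 nM, which is a limit and not a number.

Compound 3 `Cc1nc(CS(=O)(=O)c2ccc(F)cc2)c([N+](=O)[O-])n1CC(C)O` differs from compound 2 in one place: fluoro in place of hydrogen on an aromatic carbon. In words, phenyl becomes 4-fluorophenyl, with fluoro in place of hydrogen on an aromatic carbon, para to a large group. Among the compounds with values here, the only measured step, an at least 2.0-fold lower number from compound 1 to compound 2 (0.30 log units; that floor lies within the scatter), changed the chain on the aromatic nitrogen and not this ring. It therefore gives no guide to the size of the new step, and no step beyond the scatter is expected in this assay. The expectation rests on compound 2 at 418000 nM. The expected change is a 1.2-fold lower number from compound 2 to compound 3 (0.08 log units; within the scatter). For compound 3 the estimate is 350000 nM, with an expected range from 150000 nM to 800000 nM.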

Compound 3, half-maximal inhibitory concentration: > 699000 nM
Compound 3 was reported as a limit; the forecaster's own chance of this, stated with the estimate: 25%; middle value at least 1.9-fold (0.30 log units) from the limit.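

In this assay, this is the first change shown on the phenyl ring rather than on the chain at the aromatic nitrogen, and placing fluoro para to a large group gives an at least 1.6-fold higher number from compound 2 to compound 3 (0.22 log units; that floor lies within the scatter). Fluoro at this place therefore shows no sign of stronger inhibition, yet a real weakening cannot be claimed either. The true size of the step stays unknown, because compound 3 is reported only as a limit and not as a number: the limit of > 699000 nM in this assay, at which 1 of the 3 values shown sits.

Whether an amine or a carboxylic acid at this same ring position would move the number remains open, since fluoro is the only replacement for hydrogen shown here. As far as these compounds go, it is also open whether fluoro would act the same way on the core of compound 1, because this change is seen in one pair only.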